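A sulfonamide swap: cyclopentyl replaces propyl

This account rests on a few compounds, and the source may have more. Where it says the series, first, only, none or still open, it means among the compounds named here.

The compounds here share one core and are compared in a functional assay on NCI-H1975 cells (Homo sapiens) for antiproliferative activity, read by CCK-8 assay, with a stated time of 72 h; on this read-out higher numbers stand for weaker inhibition of growth and lower numbers for stronger inhibition of growth. Compound 1, with the structure `CCCNS(=O)(=O)c1ccc(Nc2ncc3c(n2)N(C2CCCC2)[C@H](CC)C(=O)N3C)cc1`, carries a propylsulfamoyl group on an aniline ring; in this assay compound 1 gives 2100 nM. Among the compounds with values here, compound 2, `CC[C@@H]1C(=O)N(C)c2cnc(-n3ccc4cc(F)ccc43)nc2N1C1CCCC1`, replaces that aniline with a fluorinated indole and gives 46500 nM in this assay, a number that sits far above the one for compound 1, beyond the usual scatter. Compound 3, `CCC1C(=O)N(C)c2cnc(-n3ccc4cc(C(N)=O)ccc43)nc2N1c1ccn(C)n1`, has an indole bearing a carboxamide and a different substituent on the core nitrogen; in this assay compound 3 is reported as "not active" (no number reported), with no number given. Among the two numbers available, compound 1 therefore stands lowest, that is, it inhibits growth most strongly.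

Compound 4, `CC[C@@H]1C(=O)N(C)c2cnc(Nc3ccc(S(=O)(=O)NC4CCCC4)cc3)nc2N1C1CCCC1`, keeps the whole of compound 1 apart from one change: cyclopentyl in place of propyl on a sulfonamide nitrogen. Within the data shown here, no measured pair in this set shows what such a change does, so the expectation rests on the small size of the change and the fact that the rest of the molecule stays the same. The step is expected to be small, plausibly within the scatter in either direction, and the estimate for compound 4 in this assay is 1600 nM, with a range from 500 nM to 5000 nM, meaning an expected step of a 1.3-fold lower number from compound 1 to compound 4 (0.12 log units; within the scatter).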

Compound 4, concentration for 50% growth inhibition: 1710 nM
For compound 4 the middle estimate is 1.1-fold (0.03 log units) below the measured one; the range from low to high includes it.
By their numbers in this assay, from the lowest: compounds 4 and 1 (each within the scatter of the next); then compound 2.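

Putting cyclopentyl in place of propyl on a sulfonamide nitrogen gives a 1.2-fold lower number from compound 1 to compound 4 (0.09 log units; within the scatter) in this assay. Within the data shown here, this is the first step in the set between compounds that differ in one place, and it shows that a ring of carbon can stand on this nitrogen instead of an open chain with no change in growth inhibition beyond the scatter, so on this read-out propyl and cyclopentyl cannot be told apart here. Nothing available explains this flat result, which therefore remains a plain observation.

Still open, on these data alone, is whether this nitrogen is as indifferent to groups of a different kind, such as a longer chain like hexyl, a chain ending in an amine or a carboxylic acid, a hydroxyl-bearing chain, or a phenyl ring, any of which could test the limits of what fits at this place. Also open, as far as these compounds go, is how far the finding reaches, since this is a single pair in a single cell line, and one pair cannot show whether the same swap would behave alike on a different core.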